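The source may report more compounds than this note shows. Statements on the series, on what has been measured and on what is new or still open speak of the compounds shown alone.

Compound 1 (`Cc1ccccc1COc1ccc2c(c1)[C@@H](O)CN(C)C2`) carries a 2-methylphenyl group on a saturated chain carbon bound to an oxygen on an aromatic ring. In an ADME assay on Vero cells (Chlorocebus sabaeus) for cytotoxicity, read by sulforhodamine B assay, with a stated time of 72 h (a higher number here means a weaker inhibitor, a lower number a stronger inhibitor), compound 1 gives only a limit, > 100000 nM, and no number. This is the limit of the assay, at the limit of > 100000 nM in this assay, at which 1 of the 3 values shown sits, so compound 1 cannot be placed on the scale beyond it. Two other compounds share the core of compound 1: compound 2 (`CCCCCCCCCCCCOc1ccc2c(c1)[C@@H](O)CN(C)C2`), which in this assay gives 18300 nM, and compound 3 (`CN1Cc2ccc(O[Si](c3ccccc3)(c3ccccc3)C(C)(C)C)cc2[C@@H](O)C1`), which in this assay gives 19100 nM; the values of compound 2 and compound 3 lie within the scatter of each other.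

Compound 4 (`CN1Cc2ccc(OCc3ccc(Br)cc3)cc2[C@@H](O)C1`) has not yet been measured. It differs from compound 1 in one place:

4-bromophenyl in place of 2-methylphenyl on a saturated chain carbon bound to an oxygen on an aromatic ring

Going by the values given here, no step between two measured compounds is known that would set the size of this change, so compound 1 is the only anchor, and it stands at a limit. The step from compound 1 to compound 4 in this assay is expected to be small, an at least 1.2-fold lower number from compound 1 to compound 4 (0.09 log units; that floor lies within the scatter), with no direction beyond the scatter. Compound 4 is expected to give about 80000 nM in this assay, with a range from 30000 nM to 150000 nM, and a fair chance that again only a limit is reported.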

Compound 4, half-maximal inhibitory concentration: 37000 nM
For compound 4 the middle estimate is 2.2-fold (0.33 log units) above the measured one, and the stated range covers the measured number.
By their numbers in this assay, from the lowest: compounds 2, 3 and 4 (each within the scatter of the next, the first and the last beyond it). At a limit, above all of these: compound 1.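

Replacing 2-methylphenyl with 4-bromophenyl on a saturated chain carbon bound to an oxygen on an aromatic ring gives an at least 2.7-fold lower number from compound 1 to compound 4 (0.43 log units; beyond the scatter). This place therefore responds to the group it carries, even in an exchange where both groups have the same count of heavy atoms and each holds one six-membered aromatic ring of carbon only. With this change, compound 4 gives a number in this assay, 37000 nM, so a group at this place now stands on the measured scale. The step remains a floor and its full size stays unknown because compound 1 has no number: the limit of > 100000 nM in this assay, at which 1 of the 4 values shown sits.

The compounds shown leave open whether the step follows from the bromine, from where the group on the ring sits, or from the loss of the methyl, since 2-bromophenyl, 4-methylphenyl and unsubstituted phenyl are not among them. They also leave open how this place would respond to a group of another kind on the ring, such as an amine or a carboxylic acid.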